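The source may report more compounds than this note shows. Statements on the series, on what has been measured and on what is new or still open speak of the compounds shown alone.

Measured so far in an in vitro ADME assay on microsomes from liver (Mus musculus) for pharmacokinetics, read by LC-MS, with a stated time of 10 min, tested at 1 uM; a higher number here means faster removal of the compound, a lower number slower removal:
- compound 1 (`CC(C)c1ccc(NC(=O)[C@H]2CN(C)C[C@@H]2c2ccc(/C=C/C(=O)Nc3ccccc3N)cc2)cc1`) gives 54 mL/min/kg
- compound 2 (`CN1C[C@H](C(=O)NC2CCCC2)[C@@H](c2ccc(/C=C/C(=O)Nc3ccccc3N)cc2)C1`) gives 61 mL/min/kg

In this assay, within the data shown here, compound 2 gives 61 mL/min/kg and lies within the scatter of compound 1, the only other compound measured so far. Among the measured compounds shown here, the single measured step (a 1.1-fold higher number from compound 1 to compound 2 (0.05 log units; within the scatter)) put cyclopentyl in place of 4-isopropylphenyl on an amide-type nitrogen.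

Compound 3 (`CN1C[C@H](C(=O)N2CCCCC2)[C@@H](c2ccc(/C=C/C(=O)Nc3ccccc3N)cc2)C1`) differs from compound 2 in one place (piperidin-1-yl in place of cyclopentylamino on a carbonyl carbon), with piperidin-1-yl in place of cyclopentylamino on a carbonyl carbon. For the measured compounds named here, no measured compound carries piperidin-1-yl, so the data offer no direct precedent, and the measured step bears on this change only loosely. Even so, that exchange of one group for a very different one left the number within the scatter (a 1.1-fold higher number from compound 1 to compound 2 (0.05 log units; within the scatter)). No shift beyond the scatter is therefore expected in either direction, and the expected step is small (a 1.1-fold lower number from compound 2 to compound 3 (0.02 log units; within the scatter)). The estimate for compound 3 is 58 mL/min/kg, with an expected range from 32 mL/min/kg to 100 mL/min/kg in this assay as the measurement is awaited.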

Compound 3, clearance: 42 mL/min/kg
Beside the measured number, compound 3's estimate is 1.4-fold (0.14 log units) above it, within the range that was stated.
By their numbers in this assay, from the lowest: compounds 3, 1 and 2 (each within the scatter of the next).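

In this assay, the exchange on the carbonyl carbon gave a 1.5-fold lower number from compound 2 to compound 3 (0.16 log units; within the scatter) and so kept the number within the scatter, although the amide hydrogen of cyclopentylamino is absent from piperidin-1-yl, which has no hydrogen-bond donor. Among these compounds, the exchange of (4-isopropylphenyl)amino for the same group gave a 1.3-fold lower number from compound 1 to compound 3 (0.11 log units; within the scatter) and also stayed within the scatter, so that all three groups at this place, two with the amide hydrogen and one without it, now stand within the scatter of one another, where the earlier pair had compared only two groups that both carry that hydrogen. Nothing given here accounts for these numbers, and the three values alone cannot say what governs removal of these compounds.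

As far as these compounds go, it remains open whether a group with a further hetero atom or a charge at this place, such as morpholin-4-yl, 4-methylpiperazin-1-yl or a carboxylic acid carried on a short chain, would move the number beyond the scatter. Also open, from the compounds shown here alone, is whether an exchange elsewhere on the shared core, for example of the methyl on its ring nitrogen for a longer chain, would do so.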